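Shrinking the Ring on the Urea Nitrogen

The source may hold more compounds than are shown below. What is called first, only, known or untested is meant among the compounds shown, and "the series" means these compounds.

Compound 1 `Cc1ccc(NC(=O)Nc2cccc(CNc3nccnc3Cl)c2)cc1Cl` and compound 2 `O=C(Nc1cccc(CNc2nccnc2Cl)c1)NC1CCCCC1` share one core and differ only in the group carried by an amide-type nitrogen. In a functional assay on MGC-803 cells (Homo sapiens) for antiproliferative activity, read by MTT assay, with a stated time of 48 h (on this read-out higher numbers stand for weaker inhibition and lower numbers for stronger inhibition), compound 1 gives 17500 nM. For compound 2 the same assay reports only a limit, > 40000 nM. The step of an at least 2.2-fold higher number from compound 1 to compound 2 (0.35 log units; beyond the scatter) is thus itself only a bound, since compound 2 sits at the limit of > 40000 nM in this assay, at which 1 of the 2 values shown sits. Compound 3 `O=C(Nc1cccc(CNc2nccnc2Cl)c1)NC1CCCC1` has not been measured; it differs from compound 2 by cyclopentyl in place of cyclohexyl on an amide-type nitrogen. Among the compounds with values here, the one measured step concerns a different exchange on that nitrogen, so nothing measured bears directly on trimming the ring by one carbon. Compound 3 is expected to stay near the limit, with an expected step that the limit leaves unreadable from compound 2 to compound 3. Compound 3 is estimated at 45000 nM, in a range from 18000 nM to 120000 nM, most likely reported again only as a limit.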

Compound 3, half-maximal inhibitory concentration: 23400 nM
Compound 3: middle estimate off by 1.9-fold (0.28 log units), on the high side; the measured number falls inside the stated range.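

Replacing cyclohexyl with cyclopentyl on this nitrogen brings a measurable number into this assay, with an at least 1.7-fold lower number from compound 2 to compound 3 (0.23 log units; that floor lies within the scatter). Compound 2 carries a limit and not a number, so that step is only a floor, and the true gap between the two rings stays unknown: the limit of > 40000 nM in this assay, at which 1 of the 3 values shown sits.

The other comparison gives a 1.3-fold higher number from compound 1 to compound 3 (0.13 log units; within the scatter), so on this nitrogen cyclopentyl stands level with 3-chloro-4-methylphenyl in this read-out, something the earlier pair did not show, since there the saturated ring gave only a limit.

The compounds shown leave open how small the group on this nitrogen can become, for instance whether a cyclobutyl ring or an open isopropyl chain would keep a measurable number. They also leave open whether a ring containing nitrogen, such as piperidine, would behave like cyclopentyl.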